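The source may report more compounds than this note shows. Statements on the series, on what has been measured and on what is new or still open speak of the compounds shown alone.

Measured compounds in an ADME assay on microsomes from liver (Mus musculus) for metabolic stability, read by LC-MS, using NADPH, with stated times of 10 min and 30 min; a lower number here means slower removal, a higher number faster removal of the compound:
- compound 1, `CC[C@H]1c2cc(Cl)ccc2C(=O)N1c1cncc2c1CCC[C@H]2NC(C)=O`: < 20.2 mL/min/kg
- compound 2, `CCC1c2cc(Cl)ccc2C(=O)N1c1cccnc1`: 65.9 mL/min/kg
- compound 3, `CC1CN(c2cccnc2)C(=O)c2ccc(Cl)cc21`: 45 mL/min/kg

Compound 1 stands at the low end of the three numbers. Its reading is a limit of this assay rather than a number: compound 1 sits at the limit of < 20.2 mL/min/kg in this assay, at which 1 of the 3 values shown sits. Compound 2 gives 65.9 mL/min/kg and compound 3 gives 45 mL/min/kg; both are plain numbers, and both lie higher than where compound 1 is reported.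

Compound 4, `CCC(=O)N[C@@H]1CCCc2c1cncc2N1C(=O)c2ccc(Cl)cc2[C@@H]1CC`, is not yet measured. It differs from compound 1 in one place: methyl in place of hydrogen on a saturated chain carbon bound to a carbonyl carbon. For the measured compounds named here, no step between measured compounds touches this position, so there is nothing measured to set the size of the change.

The expectation for compound 4 is a step that the limit leaves unreadable from compound 1 to compound 4 that stays within the usual scatter, with the reading again likely to fall at the limit. The estimated value for compound 4 in this assay is 20 mL/min/kg, with a range from 10 mL/min/kg to 40 mL/min/kg.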

Compound 4, clearance: < 20.2 mL/min/kg
Compound 4 ended at the assay's limit; the forecaster's own chance of this, stated with the estimate: 45%; the middle value lies beyond the limit too.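

In this assay, for the compounds shown here, compound 1 and compound 4 both read as limits rather than numbers, so no step between them can be read: the limit of < 20.2 mL/min/kg in this assay, at which 2 of the 4 values shown sit. The compounds shown leave open how far going from acetamido to propanoylamino moves clearance on the core of compound 1.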